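This account rests on a few compounds, and the source may have more. Where it says the series, first, only, none or still open, it means among the compounds named here.

In a functional assay on L1210 cells (Mus musculus) for inhibition (on this read-out lower numbers stand for stronger inhibition and higher numbers for weaker inhibition), compound 1 `Cc1cccc(/C=C2\CCCc3ccccc3C2=O)c1` reads 54400 nM and compound 2 `O=C1CCCCC/C1=C\c1ccc(F)cc1` reads 291000 nM on the same scale, so compound 2 holds the higher number of the two, with a gap beyond the usual scatter. These two compounds differ in more than one place, so that gap cannot be tied to any single group. Compound 3 `COc1ccc(/C=C2\CCCCCC2=O)cc1` departs from compound 2 by methoxy in place of fluoro on an aromatic carbon, and methoxy in place of fluoro on an aromatic carbon is the whole difference. Going by the values given here, no measured pair shows this change, so any forecast remains loose. Only a small move towards a lower number in this assay is expected, possibly nothing beyond the scatter, and the estimated size is a 1.4-fold lower number from compound 2 to compound 3 (0.14 log units; within the scatter) at the middle of the forecast. The estimate for compound 3 is 210000 nM within an expected range from 80000 nM to 450000 nM as the likely span.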

Compound 3, half-maximal inhibitory concentration: 306000 nM
Beside the measured number, compound 3's estimate is 1.5-fold (0.16 log units) below it; low and high end bracket the measured number.
By their numbers in this assay, from the lowest: compound 1; then compounds 2 and 3 (each within the scatter of the next).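

In this assay, going by these compounds alone, methoxy in place of fluoro on an aromatic carbon, para to a group of 9 heavy atoms, gives a 1.1-fold higher number from compound 2 to compound 3 (0.02 log units; within the scatter), the only step here that can be read at a single place. At this position, the methoxy group and the fluoro group therefore cannot be told apart on this read-out, even though the methoxy group brings a hydrogen-bond acceptor that the fluoro group lacks. No supporting measurement accompanies this result, so the data offer no explanation for it. As far as these compounds go, whether an amine or a carboxylic acid at this same position would also read alike remains open. From the compounds shown here alone, it also remains open whether methoxy and fluoro would match at another place on the aromatic ring.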